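The compounds below may be only part of what the source reports. "The series", "measured", "known", "first", "only" and "open" are said of these compounds alone.

Measured so far:
- Compound 1, `COc1ccc(NC(=O)c2ccc(-c3ccc(C(=O)N(C)C)cc3C)cc2)cc1N1CCN(C)CC1`: 9.2
- Compound 2, `COc1ccc(C(=O)Nc2ccc(-c3ccc(CO)cc3C)cc2)cc1CCCN(C)C`: 8.5

Both numbers come from a functional assay (Saphenous vein) with Canis familiaris (Canis lupus familiaris) as the target; on this read-out lower numbers stand for lower potency and higher numbers for higher potency (the scale is a negative logarithm). Of the two, compound 2 gives the lower value, 8.5, and the gap to compound 1 is beyond the usual scatter of repeated measurements. Going by the values given here, the two compounds differ in several places at once, so no single structural step between them can be read off.

Compound 3, `COc1ccc(C(=O)Nc2ccc(-c3ccc(C(=O)O)cc3C)cc2)cc1CCCN(C)C`, has not yet been measured. It differs from compound 2 in one place only: carboxy in place of hydroxymethyl on an aromatic carbon. The change swaps one small group for another of similar size on the same aromatic carbon, and the rest of the molecule is kept. Among the compounds with values here, with no comparable step among the measured compounds, the direction is uncertain; the expected step is a number 0.40 log units lower from compound 2 to compound 3 (beyond the scatter), a modest loss in this assay. The value expected for compound 3 is 8.1, between 7.3 and 8.9.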

Compound 3, negative logarithm of the antagonist equilibrium constant: 8.7
Estimate against measurement, compound 3: 0.60 log units below; the range from low to high includes it.
By their numbers in this assay, from the lowest: compounds 2 and 3 (each within the scatter of the next); then compound 1.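

Going by these compounds alone, putting carboxy in place of hydroxymethyl on this aromatic carbon gives, in this assay, a number 0.20 log units higher from compound 2 to compound 3 (within the scatter) and so gives the first reading at a single place, which the earlier pair, differing in several places at once, could not offer. At this position, meta to a methyl group and para to a large group, the two groups cannot be told apart on this read-out, even though carboxy brings one more heavy atom and a double bond. Nothing measured here offers an explanation for this result.

On these data alone, whether an amine, a methyl ester or a longer chain on the same carbon would also stay within the scatter of compound 2 remains open. Also open, as far as these compounds go, is whether hydroxymethyl and carboxy would stay this close on the core of compound 1.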